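Hydroxyamino for Cyclopropylamino: Expected Cytotoxicity of Compound 4

A few compounds are considered here, and "the series" means these few. Any claim that something is new, unique, unknown or untested is made for them only; others in the source may bear on it.

Compound 1 `N#C/C=C/c1ccc(C(NC2CC2)c2ccnc(Nc3ccc(C#N)cc3)n2)cc1` gives 56100 nM in an ADME assay on MT4 cells (Homo sapiens) for cytotoxicity, read by MTT assay, with a stated time of 5 days (a lower number here means that less compound is tolerated, a higher number that more compound is tolerated), the top of the three numbers shown, though within the scatter of compound 2 `CC(C)NC(c1ccnc(Nc2ccc(C#N)cc2)n1)c1ccccc1Cl` with 35500 nM and of compound 3 `N#Cc1ccc(Nc2nccc(C(NC3CC3)c3ccc(C#N)cc3)n2)cc1` with 34700 nM. The only single-place step among these, a 1.6-fold lower number from compound 1 to compound 3 (0.21 log units; within the scatter), stayed within the scatter. Compound 4 `N#C/C=C/c1ccc(C(NO)c2ccnc(Nc3ccc(C#N)cc3)n2)cc1` differs from compound 1 by hydroxy in place of cyclopropyl on an amine nitrogen; cut one bond further out, the change reads cyclopropylamino to hydroxyamino. Within the data shown here, no measured pair shows this exchange, and compound 2 differs from compound 1 in more than one place, so no step bears on it directly. The step of a 1.1-fold lower number from compound 1 to compound 4 (0.05 log units; within the scatter) is therefore expected to stay within the scatter. Compound 4 is estimated at 50000 nM, with a range from 20000 nM to 150000 nM.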

Compound 4, half-maximal cytotoxic concentration: 161000 nM
The estimate for compound 4 lay 3.2-fold (0.51 log units) below the measured number; measured number above the stated range.
By their numbers in this assay, from the lowest: compounds 3, 2 and 1 (each within the scatter of the next); then compound 4.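

In this assay, hydroxy in place of cyclopropyl on an amine nitrogen gives a 2.9-fold higher number from compound 1 to compound 4 (0.46 log units; beyond the scatter), the only single-place step shown that lies beyond the scatter. The other such step, at an aromatic carbon, stayed within it, so this amine nitrogen is the one place shown where a change moves the number, here towards more compound tolerated. Nothing shown gives a reason for this shift.

Going by these compounds, whether methoxy or ethyl on this amine nitrogen would follow hydroxy or cyclopropyl remains open. So does whether the step holds with cyano in place of 2-cyanoethenyl.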